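Swapping the Sulfonyl Aryl Group: Estimating Compound 3 Clearance

The compounds below may be only part of what the source reports. "The series", "measured", "known", "first", "only" and "open" are said of these compounds alone.

Compound 1 `N#Cc1cccc(S(=O)(=O)c2cnc3cc(F)ccc3c2-c2cccc(Cl)c2)c1` gives 0.99 mL/min in an ADME assay on microsomes from liver (Homo sapiens) for metabolic stability, tested at 2.5 uM; on this read-out lower numbers stand for slow clearance and higher numbers for fast clearance.
Compound 2 `O=S(=O)(c1ccc(F)c(Cl)c1)c1cnc2cc(F)ccc2c1-c1cccc(Cl)c1` gives 0.66 mL/min in this assay.

Going by the values given here, compound 2 stands at the lowest of the two numbers in this assay, but its only neighbour is compound 1, and the step of a 1.5-fold lower number from compound 1 to compound 2 (0.18 log units; within the scatter) lies within the scatter, so the two compounds cannot be told apart on what has been measured. Both share the same core; they differ only in the aryl group attached to the sulfonyl sulfur.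

Compound 3 `Cc1ccc(S(=O)(=O)c2cnc3cc(F)ccc3c2-c2cccc(Cl)c2)cc1F` differs from compound 2 in one place: 3-fluoro-4-methylphenyl in place of 3-chloro-4-fluorophenyl on a sulfonyl sulfur. Among the compounds with values here, the one measured step, a 1.5-fold lower number from compound 1 to compound 2 (0.18 log units; within the scatter), also exchanged one aryl group on the sulfonyl sulfur for another and produced no change beyond the scatter. Within the data shown here, no measured compound carries a 3-fluoro-4-methylphenyl, so nothing here points to a large move in either direction for compound 3. The step from compound 2 to compound 3 in this assay is therefore expected to be small, a 1.4-fold higher number from compound 2 to compound 3 (0.13 log units; within the scatter), and within the scatter. For compound 3 the estimate in this assay is 0.9 mL/min, with a range from 0.45 mL/min to 1.8 mL/min.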

Compound 3, intrinsic clearance in a liver preparation (reported as CLH), per the amount of preparation that the assay uses: 2.13 mL/min
The estimate for compound 3 lay 2.4-fold (0.37 log units) below the measured number; measured number outside the range, above it.
By their numbers in this assay, from the lowest: compounds 2 and 1 (each within the scatter of the next); then compound 3.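

In this assay the aryl group on the sulfonyl sulfur turns out to be able to move the number beyond the scatter: 3-fluoro-4-methylphenyl in place of 3-chloro-4-fluorophenyl gives a 3.2-fold higher number from compound 2 to compound 3 (0.51 log units; beyond the scatter) and 3-fluoro-4-methylphenyl in place of 3-cyanophenyl gives a 2.2-fold higher number from compound 1 to compound 3 (0.33 log units; beyond the scatter) as well. The first two compounds could not show this, since their numbers lie within the scatter of each other, whereas both new steps are modest but point the same way and put compound 3 alone at the fast-clearance end of these three compounds. The entering and leaving groups have the same count of heavy atoms, yet the number still shifts, and no measurement shown here offers an explanation for that shift.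

The exchange from compound 2 to compound 3 alters the group in more than one atom, with the chlorine gone and a methyl present, so these compounds cannot tell which part of it goes with the higher number. On these data alone, how the number would respond to a sulfonyl aryl group carrying an amine, a carboxylic acid or a longer chain such as propyl remains open.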